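Adding a Methyl to Compound 2's Four-Membered Ring

This account rests on a few compounds, and the source may have more. Where it says the series, first, only, none or still open, it means among the compounds named here.

Compound 1 `OC(c1ncccc1F)C1(c2ccc(Cl)c(Cl)c2)CCC1`: 833 mL/min/kg
Compound 2 `O[C@H](c1ccccn1)[C@]1(c2cc(C(F)(F)F)ccn2)C[C@H](O)C1`: 33.3 mL/min/kg

In an ADME assay on liver for metabolic stability, with Liver microsome (Homo sapiens) as the target, read by LC-MS, using microsomes, with a stated time of 5 h (on this read-out lower numbers stand for slow clearance and higher numbers for fast clearance), compound 2 has the lower of the two numbers, at 33.3 mL/min/kg, and compound 1 has the higher, at 833 mL/min/kg, a gap well beyond the scatter. These two compounds differ in more than one place, so they give no single-change step to reason from.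

Compound 3 `C[C@]1(O)C[C@](c2cc(C(F)(F)F)ccn2)([C@H](O)c2ccccn2)C1` differs from compound 2 in one place: methyl in place of hydrogen on a saturated ring carbon. Within the data shown here, no measured pair shows the effect of this change in this assay. The expectation therefore starts from compound 2 at 33.3 mL/min/kg, with no step beyond the scatter expected in either direction. The estimated change is a 1.0-fold lower number from compound 2 to compound 3 (0.00 log units; within the scatter). For compound 3 the estimated clearance is 33 mL/min/kg, with an expected range of 14 mL/min/kg to 80 mL/min/kg.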

Compound 3, clearance: 33.3 mL/min/kg
Beside the measured number, compound 3's estimate is 1.0-fold (0.00 log units) below it; low and high end bracket the measured number.
By their numbers in this assay, from the lowest: compounds 2 and 3 (each within the scatter of the next); then compound 1.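

In this assay, methyl in place of hydrogen on a saturated ring carbon of the four-membered ring gives no change at the digits printed from compound 2 to compound 3 (within the scatter) and is the first single-change step among these compounds. Compound 1 and compound 2 differ in more than one place and could not isolate this position, whereas this step shows that, on the core of compound 2, the added methyl leaves the clearance reading within the scatter. Nothing available accounts for this outcome at the ring carbon.

The compounds shown leave open whether an ethyl, a methoxy or an amine at this ring carbon would also leave the number in place. They also leave open whether the same methyl would give a similar step on the core of compound 1.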